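The source may hold more compounds than are shown below. What is called first, only, known or untested is meant among the compounds shown, and "the series" means these compounds.

Working notes on the series start from three compounds with a shared core: compound 1 (`Cc1ccc(Cn2c(=O)[nH]c3c(N)nc(C(F)(F)F)cc32)nn1`), compound 2 (`Cc1nc(Cn2c(=O)[nH]c3c(N)nc(C(F)(F)F)cc32)co1`) and compound 3 (`Nc1nc(C(F)(F)F)cc2c1[nH]c(=O)n2Cc1ccc(C(F)(F)F)nc1`). In an in vitro ADME assay on microsomes from liver (Rattus norvegicus) for metabolic stability (a higher number here means faster removal of the compound, a lower number slower removal), compound 1 gives < 11 mL.min-1.g-1 as a limit and not a number. Compound 2 gives < 10 mL.min-1.g-1 as a limit as well. Compound 3 gives < 8.5 mL.min-1.g-1 as a limit too, so it has no number of its own, and neither does any other compound here.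

The next compound is compound 4 (`Nc1nc(C(F)(F)F)cc2c1[nH]c(=O)n2Cc1ccc(NCC2CC2)nc1`), not yet measured. It carries (cyclopropylmethyl)amino in place of trifluoromethyl on an aromatic carbon, next to the ring nitrogen.

Within the data shown here, only one measured step exists, and a step that the two limits leave unreadable from compound 1 to compound 2 gives no size to carry over. It also exchanges a different group at a different place. Among the measured compounds shown here, no measured compound carries the entering group, so the expectation rests on the structural change alone and remains loose. The expected step is an at least 2.1-fold higher number from compound 3 to compound 4 (0.32 log units; beyond the scatter) in the direction of faster removal in this assay as a judgement only. For compound 4 the estimate is 18 mL.min-1.g-1 with an expected range from 7 mL.min-1.g-1 to 50 mL.min-1.g-1 in this read-out.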

Compound 4, intrinsic clearance in microsomes in the Rattus norvegicus assay: 85 mL.min-1.g-1
For compound 4 the middle estimate is 4.7-fold (0.67 log units) below the measured one; measured number above the stated range.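

Among these compounds, in the Rattus norvegicus assay the exchange of trifluoromethyl for (cyclopropylmethyl)amino on an aromatic carbon, next to the ring nitrogen, gives an at least 10-fold higher number from compound 3 to compound 4 (1.00 log units; beyond the scatter), with compound 4 at 85 mL.min-1.g-1, the first step with a readable size, while the step between compound 1 and compound 2 cannot be read. Among the compounds shown here, this shows that the group at this place can matter greatly in this assay, something the earlier compounds could not show, since compound 4 is the first here with a number of its own. In the Rattus norvegicus assay compound 3 gives < 8.5 mL.min-1.g-1, which is a limit and not a number: the limit of < 8.5 mL.min-1.g-1 in the Rattus norvegicus assay, at which 1 of the 4 values shown sits.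

The compounds shown do not separate the parts of the entering group, so no cause can be given for the step, and it stays open whether it goes with the ring-bearing chain or with the amine nitrogen, which a plain amino group or a methoxy group at the same place could help to tell. In a physicochemical assay for lipophilicity, measured as octanol-water partition, at pH 7.4 (on this read-out higher numbers stand for higher lipophilicity and lower numbers for lower lipophilicity), compound 3 gives "not determined" (no result reported), so no result is reported for it. For the compounds shown here, in the physicochemical assay compound 4 gives 3.2, but this value stands alone with no step to set it against, so its link to the result in the Rattus norvegicus assay also stays open.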